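The compounds below may be only part of what the source reports. "The series", "measured", "known", "first", "only" and "open" are said of these compounds alone.

For the measured compounds named here, compound 2 `COc1ccc(/C=N/NC(N)=S)c2ccccc12` gives 42000 nM in a toxicity assay on MRC5 cells (Homo sapiens) for cytotoxicity, read by MTT assay, with a stated time of 72 h (a higher number here means that more compound is needed for the effect, a lower number that less compound is needed), the only plain number in the set. Compound 1 `NC(=S)N/N=C/c1ccc(F)c2ccccc12` reaches only a limit in this assay, > 200000 nM, not a number. The step of an at least 4.7-fold lower number from compound 1 to compound 2 (0.67 log units; beyond the scatter) is therefore bounded by the limit of > 200000 nM in this assay, at which 1 of the 2 values shown sits. Compound 3 `CCOc1ccc(/C=N/NC(N)=S)c2ccccc12` differs from compound 2 by methyl in place of hydrogen on a saturated chain carbon bound to an oxygen on an aromatic ring. Going by the values given here, no measured step touches a saturated chain carbon bound to an oxygen on an aromatic ring, so none bears directly on this change; a step within the scatter is expected, in neither direction. Compound 3 is estimated at 40000 nM, between 15000 nM and 120000 nM. The expected step is a 1.1-fold lower number from compound 2 to compound 3 (0.02 log units; within the scatter).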

Compound 3, half-maximal effective concentration: > 200000 nM
Compound 3: no number, only a limit (the forecaster's own chance of this, stated with the estimate: 20%); at least 5.0-fold (0.69 log units) between middle value and limit.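

In this assay the saturated chain carbon bound to an oxygen on an aromatic ring is sensitive to methyl in place of hydrogen, with an at least 4.7-fold higher number from compound 2 to compound 3 (0.67 log units; beyond the scatter) as the step, so methoxy to ethoxy is not a neutral change here. Methoxy is the only group shown that gives a plain number. The size of this step stays a bound and the step between compound 1 and compound 3 cannot be read, because the values sit at a limit: the limit of > 200000 nM in this assay, at which 2 of the 3 values shown sit.

From the compounds shown here alone, whether a longer chain such as propoxy also stays at the limit remains open. So does the outcome with an amine at this place on the shared core.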